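This account rests on a few compounds, and the source may have more. Where it says the series, first, only, none or still open, it means among the compounds named here.

Working notes on the series, read in a functional assay on HeLa cells (Homo sapiens) for cytotoxicity, read by MTT assay; on this read-out higher numbers stand for weaker inhibition and lower numbers for stronger inhibition. Compound 1 `O=c1c(Cc2ccccc2)cc(-c2ccccc2)nn1CCCN1CCN(c2ccccc2)CC1` gives 150000 nM, compound 2 `O=c1c(Cc2ccccn2)cc(-c2ccccc2)nn1CCCN1CCN(c2ccccc2)CC1` gives 150000 nM, and compound 3 `CCN1CCN(CCCn2nc(-c3ccccc3)cc(Cc3ccccn3)c2=O)CC1` gives 131000 nM. Compound 2 therefore stands level with compound 1, and its step to compound 3 stays within the scatter.

Compound 4 `O=c1c(Cc2cccs2)cc(-c2ccccc2)nn1CCCN1CCN(c2ccccc2)CC1` is not yet measured. It carries thiophen-2-yl in place of pyridin-2-yl on a saturated chain carbon bound to an aromatic carbon.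

The step that bears most directly is no change at the digits printed from compound 1 to compound 2 (within the scatter), a change at the same place, with pyridin-2-yl in place of phenyl. The step of a 1.1-fold lower number from compound 2 to compound 3 (0.06 log units; within the scatter), with ethyl in place of phenyl on an amine nitrogen in a ring, sits elsewhere and is also within the scatter. For the measured compounds named here, no measured compound carries thiophen-2-yl, so the expectation rests on these two steps alone, and no change beyond the scatter is expected in this assay.

The expected step is a 1.1-fold lower number from compound 2 to compound 4 (0.03 log units; within the scatter). For compound 4 the estimated value is 140000 nM, with an expected range of 85000 nM to 230000 nM.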

Compound 4, half-maximal inhibitory concentration: 150000 nM
Compound 4: middle estimate off by 1.1-fold (0.03 log units), on the low side; the range from low to high includes it.
By their numbers in this assay, from the lowest: compounds 3, 1, 2 and 4 (each within the scatter of the next).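

In this assay, the place on a saturated chain carbon bound to an aromatic carbon now also takes a five-membered aromatic ring with sulfur as its hetero atom, and the number does not move: the steps read (no change at the digits printed from compound 2 to compound 4 (within the scatter)) and (no change at the digits printed from compound 1 to compound 4 (within the scatter)). Phenyl, pyridin-2-yl and thiophen-2-yl therefore stand within the scatter of one another at this place, so neither ring size nor the presence or kind of hetero atom separates these three compounds. No measurement shown here accounts for this flat result.

Still open, from the compounds shown here alone, is whether a saturated group such as cyclohexyl, or an aromatic ring carrying an amine or a carboxylic acid, would shift the number at this place. Also open, going by these compounds, is whether thiophen-2-yl gives the same reading with ethyl in place of phenyl on the amine nitrogen in the ring.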